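The source may hold more compounds than are shown below. What is called first, only, known or untested is meant among the compounds shown, and "the series" means these compounds.

Series notes. In a physicochemical assay for solubility, read by HPLC, in simulated intestinal fluid, with a stated time of 16 h, tested at 125 ug/mL (a lower number here means a less soluble compound, a higher number a more soluble compound), compound 1 `CNC(=O)c1cc(C(=O)NC2CC2)c(C)n(Cc2ccccc2)c1=O` gives 577 ug/mL, and compound 3 `CNC(=O)c1cc(C(=O)NC2CCC2)cn(Cc2ccccn2)c1=O` gives 920 ug/mL. Compound 2 `CNC(=O)c1cc(C(=O)NC2CC2)cn(Cc2cccc3[nH]ccc23)c1=O` gives 17 ug/mL in this assay, the lowest of the three numbers; its gaps to compound 1 and to compound 3 both lie beyond the scatter. Compound 4 `CNC(=O)c1cc(C(=O)NC2CC2)cn(Cc2cccc3cc[nH]c23)c1=O` is not yet measured. It differs from compound 2 by 1H-indol-7-yl in place of 1H-indol-4-yl on a saturated chain carbon bound to an aromatic nitrogen; the two have the same atoms, joined differently. Within the data shown here, no step between two measured compounds reflects a change of this kind, so the expected step of a 1.5-fold higher number from compound 2 to compound 4 (0.17 log units; within the scatter) is taken as small, in either direction, and probably within the scatter. Compound 4 is therefore expected to give about 25 ug/mL, within a range from 8 ug/mL to 80 ug/mL.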

Compound 4, solubility: 11 ug/mL
The estimate for compound 4 lay 2.3-fold (0.36 log units) above the measured number; the measured number falls inside the stated range.
By their numbers in this assay, from the lowest: compounds 4 and 2 (each within the scatter of the next); then compounds 1 and 3 (each within the scatter of the next).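

In this assay, 1H-indol-7-yl in place of 1H-indol-4-yl on a saturated chain carbon bound to an aromatic nitrogen gives a 1.5-fold lower number from compound 2 to compound 4 (0.19 log units; within the scatter) and stays within the scatter. Among these compounds, this is the first step read at this position, and it shows that the two attachment points of the indole are not told apart in this read-out.

Still open, going by these compounds, is how a carboxylic acid or an amine in place of 1H-indol-4-yl at this same place would read in this assay. No measured evidence bears on the size of this step.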